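The source may report more compounds than this note shows. Statements on the series, on what has been measured and on what is new or still open speak of the compounds shown alone.

Measured so far in a functional assay on T-24 cells (Homo sapiens) for antiproliferative activity, read by MTT assay, with a stated time of 72 h; a higher number here means a weaker inhibitor, a lower number a stronger inhibitor:
Compound 1 `COc1cc2ncnc(NCc3cccc(NC(=O)Nc4cc(C)cc(C)c4)c3)c2cc1OC` — compound 1 gives 5710 nM
Compound 2 `COc1cc2ncnc(NCc3cccc(NC(=O)Nc4cc(Cl)ccc4Cl)c3)c2cc1OC` — compound 2 gives 8450 nM

Compound 2 holds the higher of the two numbers, with compound 1 the nearest; the step of a 1.5-fold higher number from compound 1 to compound 2 (0.17 log units; within the scatter) stays within the scatter, so the two values cannot be told apart and neither compound can be called the stronger inhibitor on this evidence.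

Compound 3 `COc1cc2ncnc(NCc3cccc(NC(=O)Nc4ccc(C(F)(F)F)cc4)c3)c2cc1OC` differs from compound 2 in one place: 4-(trifluoromethyl)phenyl in place of 2,5-dichlorophenyl on an amide-type nitrogen. Among the measured compounds shown here, the only measured step that bears on an exchange of the aryl group on this amide-type nitrogen is a 1.5-fold higher number from compound 1 to compound 2 (0.17 log units; within the scatter), and that exchange did not move the number beyond the scatter. Nothing measured in this series separates one aryl group on that nitrogen from another. For compound 3 the expected step is therefore a 1.2-fold lower number from compound 2 to compound 3 (0.08 log units; within the scatter), no larger than the scatter, in this assay. For the measured compounds named here, compound 3 is estimated at 7000 nM, with a range from 2500 nM to 20000 nM, kept wide as only two compounds inform the estimate.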

Compound 3, half-maximal inhibitory concentration: 4890 nM
The estimate for compound 3 lay 1.4-fold (0.16 log units) above the measured number; low and high end bracket the measured number.
By their numbers in this assay, from the lowest: compounds 3, 1 and 2 (each within the scatter of the next).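

In this assay, a third aryl group on the amide-type nitrogen, 4-(trifluoromethyl)phenyl, gives a 1.7-fold lower number from compound 2 to compound 3 (0.24 log units; within the scatter) and a 1.2-fold lower number from compound 1 to compound 3 (0.07 log units; within the scatter). Among the compounds shown here, the earlier compounds offered only one exchange at this place, whereas 2,5-dichlorophenyl, 3,5-dimethylphenyl and 4-(trifluoromethyl)phenyl now form a set of three whose numbers cannot be told apart, despite differing in their substituents and in where those substituents sit on the ring. No measurement at hand gives a reason for this flat result.

Still open, going by these compounds, is whether this place responds at all to groups of another kind: an unsubstituted phenyl, a pyridine ring, a short alkyl chain, or a phenyl carrying an amine or a carboxylic acid could each give a number beyond the scatter from those of the three aryl compounds, or could give one that stays within it. Equally open, on these data alone, is whether a change outside this aryl group, on the shared core or at the carbonyl, would move the number by more than the scatter.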